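4-Cyanophenyl to 4-isopropylphenyl: clearance notes

The source may report more compounds than this note shows. Statements on the series, on what has been measured and on what is new or still open speak of the compounds shown alone.

Of the compounds shown here, three sharing one core have been read in an ADME assay on microsomes from liver (Mus musculus, strain CD1) for metabolic stability, read by HPLC, using NADPH, with a stated time of 30 min; a higher number here means faster removal of the compound, a lower number slower removal. Compound 1 `COc1cccc(NC(=O)c2nnn(Cc3ccncc3)c2N)c1` gives 0.7 mL.min-1.g-1. Within the data shown here, compound 2 `COc1cccc(NC(=O)c2nnn(Cc3ccc(C#N)cc3)c2N)c1` gives 2.5 mL.min-1.g-1, the higher of the two numbers so far. Compound 3 `COc1cccc(NC(=O)c2nnn(CC3CCNCC3)c2N)c1` gives < 0.5 mL.min-1.g-1, which is a limit of the assay and not a number.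

Compound 4 `COc1cccc(NC(=O)c2nnn(Cc3ccc(C(C)C)cc3)c2N)c1` changes compound 2 in one place, on an aromatic carbon of a six-membered aromatic ring of carbon only: isopropyl in place of cyano on an aromatic carbon. Isopropyl stands in place of cyano.

Among the measured compounds shown here, no measured step makes this exact exchange. The closest evidence replaces the whole ring group on the same chain carbon, giving a 3.6-fold higher number from compound 1 to compound 2 (0.55 log units; beyond the scatter) and an at least 5.0-fold lower number from compound 2 to compound 3 (0.69 log units; beyond the scatter). The second of these rests on (the limit of < 0.5 mL.min-1.g-1 in this assay, at which 1 of the 3 values shown sits). The remaining step, an at least 1.4-fold lower number from compound 1 to compound 3 (0.14 log units; that floor lies within the scatter), has a floor within the scatter and says little.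

A step of modest size is therefore expected in this assay. Its direction is less secure. Upward is favoured because compound 1 at 0.7 mL.min-1.g-1 carries a nitrogen in its ring, whereas only carbon enters in compound 4. The estimated move is a 2.8-fold higher number from compound 2 to compound 4 (0.45 log units; beyond the scatter). For compound 4 the expected value is 7 mL.min-1.g-1, with an estimated range of 2.5 mL.min-1.g-1 to 20 mL.min-1.g-1.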

Compound 4, intrinsic clearance in microsomes: 3.2 mL.min-1.g-1
Beside the measured number, compound 4's estimate is 2.2-fold (0.34 log units) above it; low and high end bracket the measured number.
By their numbers in this assay, from the lowest: compound 1; then compounds 2 and 4 (each within the scatter of the next). At a limit, below all of these: compound 3.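

In this assay, among these compounds, this is the first reading of a change on the aromatic carbon itself, as the earlier steps replaced the whole ring group: a 1.3-fold higher number from compound 2 to compound 4 (0.11 log units; within the scatter). Cyano and isopropyl at this place are therefore not told apart by this read-out, although they differ in the atoms listed for them. The whole-ring exchange, by contrast, still separates compounds, with a 4.6-fold higher number from compound 1 to compound 4 (0.66 log units; beyond the scatter) standing beside a 3.6-fold higher number from compound 1 to compound 2 (0.55 log units; beyond the scatter), so that both carbon-only aromatic rings read beyond the scatter from the pyridin-4-yl compound, while the remaining step, an at least 6.4-fold higher number from compound 3 to compound 4 (0.80 log units; beyond the scatter), is a floor and not a size, resting on a limit of the assay: the limit of < 0.5 mL.min-1.g-1 in this assay, at which 1 of the 4 values shown sits.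

The compounds shown leave open whether an amine or a carboxylic acid on the same aromatic carbon would be told apart from cyano and isopropyl in this assay. They also leave open whether a methoxy group there would do so, and whether any such group would keep its reading once the ring carrying it is changed.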